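A few compounds are considered here, and "the series" means these few. Any claim that something is new, unique, unknown or untested is made for them only; others in the source may bear on it.

Measured so far:
- compound 1, `C/C=C1/[C@H](O[C@@H]2O[C@H](CO)[C@@H](O)[C@H](O)[C@H]2O)OC=C(C(=O)OC)[C@H]1CC(=O)OCCc1ccc2c(c1)OCCO2`: > 20000 nM
- compound 2, `C/C=C1/[C@H](O[C@@H]2O[C@H](COC(C)=O)[C@@H](OC(C)=O)[C@H](OC(C)=O)[C@H]2OC(C)=O)OC=C(C(=O)OC)[C@H]1CC(=O)OC`: > 15000 nM

Both compounds share the same core and were tested in a functional assay on SK-BR-3 cells (Homo sapiens) for antiproliferative activity, read by MTT assay, with a stated time of 72 h; a lower number here means a stronger inhibitor, a higher number a weaker inhibitor. For compound 1 the figure > 20000 nM is a limit of this assay and not a number. For compound 2 the figure > 15000 nM is likewise a limit of this assay. Compound 1 therefore cannot be placed above or below compound 2; the two values only show that neither compound reached a measurable result in this assay.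

Compound 3, `C/C=C1/[C@H](O[C@@H]2O[C@H](CO)[C@@H](O)[C@H](O)[C@H]2O)OC=C(C(=O)OC)[C@H]1CC(=O)OCc1ccccc1`, has not yet been tested. It differs from compound 1 at one point: phenyl in place of (2,3-dihydro-1,4-benzodioxin-6-yl)methyl on a saturated chain carbon bound to an oxygen next to a carbonyl group. For the measured compounds named here, no measured pair in this set reports a step of this kind, and the limit for compound 1 gives no number from which a step could be read.

The expectation is that compound 3 will again sit at a limit of this assay, so no step beyond the scatter is expected from compound 1 to compound 3. Compound 3 is estimated at 20000 nM, with a range from 5000 nM to 60000 nM. The step this estimate implies is a number no higher from compound 1 to compound 3 (the limit leaves the size open), which is expected rather than known.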

Compound 3, half-maximal inhibitory concentration: > 15000 nM
Compound 3 gave a limit, no number; the forecaster's own chance of this, stated with the estimate: 80%; the middle value lies beyond the limit too.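

Compound 3, like compound 1, gave only a limit of the assay and no number, and no step can be read between the two. The compounds shown leave open how strongly any of them inhibits in this assay, and whether phenyl in place of (2,3-dihydro-1,4-benzodioxin-6-yl)methyl makes any difference there.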